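The compounds below may be only part of what the source reports. "The series", "measured", "known", "first", "only" and "open" are said of these compounds alone.

Measured compounds:
- compound 1 `O=C(O)CCCCOc1cc(-c2ccccc2)c2ccccc2n1`: 0%
- compound 2 `CC(C)(CCCCSc1cc(-c2ccccc2)c2ccccc2n1)C(=O)O`: 33%

In an assay on membranes from spleen (Cavia porcellus) for binding affinity to leukotriene B4 receptor 1 (Homo sapiens), tested at 10 uM (a lower number here means less inhibition, a higher number more inhibition at the concentration tested (going by the name of the read-out)), compound 1 gives 0%, the lowest of the two numbers recorded. Going by the values given here, compound 2 gives 33%, a number beyond the scatter above compound 1; no single-point step between the two is counted, since they differ in more than one place, so only the two values themselves stand.

The step under consideration goes from compound 1 to compound 3 `OCCCCCCOc1cc(-c2ccccc2)c2ccccc2n1`. The counted difference is 2-hydroxyethyl in place of carboxy on a saturated chain carbon, four bonds along the chain from an oxygen on an aromatic ring. Among the compounds with values here, the carboxy that leaves is the only group of its kind in compound 1, and compound 1 shows no inhibition to begin with. With nothing in the measured pair pointing to a gain from a 2-hydroxyethyl, the expected step in this assay from compound 1 to compound 3 is none beyond the scatter, a number 3 percentage points higher from compound 1 to compound 3 (within the scatter). Compound 3 is therefore estimated at 3%, with a range from 0% to 15%.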

Compound 3, a percentage reported as inhibition, at one concentration (the size of the read-out at that concentration, not a potency): 14%
For compound 3 the middle estimate is 11 percentage points below the measured one, within the range that was stated.
By their numbers in this assay, from the lowest: compound 1; then compound 3; then compound 2.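

In this assay the change from carboxy to 2-hydroxyethyl on a saturated chain carbon, four bonds along the chain from an oxygen on an aromatic ring, gives a number 14 percentage points higher from compound 1 to compound 3 (beyond the scatter) and so counts as a modest gain. Going by these compounds alone, at this place, then, the carboxy is not required for a reading above that of compound 1, which compound 1 and compound 2 could not show, as no step joined them. No measurement at hand accounts for this step.

Going by these compounds, whether an amine or a primary amide in place of the carboxy would match, exceed or fall short of the reading of compound 3 stays open. Within the data shown here, also open is whether a longer chain carrying the same hydroxyl would move the number further, and the single tested concentration gives no potency for either compound.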